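The compounds below may be only part of what the source reports. "The series", "measured", "known", "first", "only" and "open" are said of these compounds alone.

Compound 3 `FC(F)(F)c1cccc(-c2nc(NCc3ccc(-c4cccnc4)cc3)c3ccccc3n2)c1` carries a 3-(trifluoromethyl)phenyl group, and in an assay on a protein complex for inhibition of ubiquitin carboxyl-terminal hydrolase 1/WD repeat-containing protein 48 (Homo sapiens), read by fluorescence (a higher number here means a weaker inhibitor, a lower number a stronger inhibitor), compound 3 gives "not active" (no number reported), so no number places it among its relatives. Those relatives are compound 1 `COc1ccc(CNc2nc(-c3ccccc3C(F)(F)F)nc3ccccc23)cc1`, which in this assay gives 6200 nM, and compound 2 `FC(F)(F)c1ccccc1-c1nc(NCc2ccc(-c3ccccc3)cc2)c2ccccc2n1`, which in this assay gives 3700 nM; the step of a 1.7-fold lower number from compound 1 to compound 2 (0.22 log units; within the scatter) concerns a different part of the shared core. Compound 4 `c1cncc(-c2ccc(CNc3nc(C4CCCC4)nc4ccccc34)cc2)c1` differs from compound 3 by cyclopentyl in place of 3-(trifluoromethyl)phenyl on an aromatic carbon. No measured step touches this group, and compound 3 itself offers no number, so nothing shown sets the size or direction of the move in this assay. Compound 4 is therefore expected, with little confidence, to give about 8000 nM in this assay, within a range from 1500 nM to 50000 nM.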

Compound 4, half-maximal inhibitory concentration: "not active" (no number reported)
Compound 4 has no reported number here; the estimate stays without a comparison.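

Compound 3 and compound 4 both read "not active" in this assay, so no step can be read between them, and no evidence bears on this result. The compounds shown leave open how 3-(trifluoromethyl)phenyl and cyclopentyl compare at this place.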